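A few compounds are considered here, and "the series" means these few. Any claim that something is new, unique, unknown or untested is made for them only; others in the source may bear on it.

Compound 1 `Clc1ccc(NCc2cn(-c3ccccc3)nc2-c2ccc(Cl)cc2)cc1` has been measured in an ADME assay on MDBK cells (Bos taurus) for cytotoxicity, read by MTT assay, with a stated time of 72 h (on this read-out lower numbers stand for higher toxicity in this test and higher numbers for lower toxicity in this test), only as a limit: compound 1 gives > 100000 nM. Compound 2 `Cc1ccc(NCc2cn(-c3ccccc3)nc2-c2ccc(Cl)cc2)cc1` likewise sits at a limit, and compound 2 gives > 100000 nM. Compound 3 `FC(F)(F)c1ccc(-c2nn(-c3ccccc3)cc2CNc2ccc(Br)cc2)cc1` gives a number, 64000 nM, in this assay. Within the data shown here, the single measured step, a step that the two limits leave unreadable from compound 1 to compound 2, with methyl in place of chloro on an aromatic carbon, cannot be sized, since both ends rest at the limit of > 100000 nM in this assay, at which 2 of the 3 values shown sit. Compound 4 `Clc1ccc(NCc2cn(-c3ccccc3)nc2-c2ccccc2)cc1` differs from compound 1 by hydrogen in place of chloro on an aromatic carbon. Among the measured compounds shown here, no measured step touches this change, and the one step that exists is unreadable, so the only anchor is that two of the three measured values sit at the limit of > 100000 nM in this assay, at which 2 of the 3 values shown sit, and the third, compound 3, is not far beneath it. On that basis no step beyond the usual scatter is expected, and the step from compound 1 to compound 4 is estimated as a step that the limit leaves unreadable from compound 1 to compound 4. Compound 4 is therefore expected to give about 150000 nM in this assay, within 60000 nM to 400000 nM, most likely reported again as a limit.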

Compound 4, half-maximal cytotoxic concentration: > 100000 nM
Compound 4 was reported as a limit; the forecaster's own chance of this, stated with the estimate: 70%; the middle value is on the limit's open side.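

No step can be read between compound 1 and compound 4, as both ends rest at a limit: the limit of > 100000 nM in this assay, at which 3 of the 4 values shown sit.

The compounds shown leave open whether hydrogen or methyl in place of chloro changes cytotoxicity at all, as neither change has a numerical value at both ends.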